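A few compounds are considered here, and "the series" means these few. Any claim that something is new, unique, unknown or untested is made for them only; others in the source may bear on it.

In a functional assay on HT-29 cells (Homo sapiens) for antiproliferative activity, read by MTT assay, with a stated time of 72 h (a higher number here means a weaker inhibitor, a lower number a stronger inhibitor), compound 1 `Nc1nc(N)c2cc(CSC(=S)N3CCN(C4CCCCC4)CC3)ccc2n1` gives 4050 nM, compound 2 `COc1ccc(N2CCN(C(=S)SCc3ccc4nc(N)nc(N)c4c3)CC2)cc1` gives 1770 nM and compound 3 `Nc1nc(N)c2cc(CSC(=S)N3CCN(c4ccccc4Cl)CC3)ccc2n1` gives 3900 nM. Compound 3 cannot be told apart from compound 1, and both sit modestly above compound 2. Compound 4 `Nc1nc(N)c2cc(CSC(=S)N3CCN(c4ccccc4F)CC3)ccc2n1` makes one change to compound 3: fluoro in place of chloro on an aromatic carbon, ortho to a large group. For the measured compounds named here, no measured step alters the chloro itself. Exchanging the whole group on the amine nitrogen moved the number little: a 1.0-fold lower number from compound 1 to compound 3 (0.02 log units; within the scatter), a 2.3-fold lower number from compound 1 to compound 2 (0.36 log units; beyond the scatter) and a 2.2-fold higher number from compound 2 to compound 3 (0.34 log units; beyond the scatter). This smaller swap should therefore stay within the scatter, with no firm direction. The expected change is a 1.1-fold lower number from compound 3 to compound 4 (0.06 log units; within the scatter). For compound 4 the estimated value is 3400 nM, with an expected range of 1800 nM to 6000 nM.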

Compound 4, half-maximal inhibitory concentration: 5420 nM
The estimate for compound 4 lay 1.6-fold (0.20 log units) below the measured number; the measured number falls inside the stated range.
By their numbers in this assay, from the lowest: compound 2; then compounds 3, 1 and 4 (each within the scatter of the next).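

In this assay the halogen itself now changes, and a 1.4-fold higher number from compound 3 to compound 4 (0.14 log units; within the scatter) shows that fluoro in place of chloro on this aromatic carbon, ortho to a large group, makes no clear difference. Likewise, a 1.3-fold higher number from compound 1 to compound 4 (0.13 log units; within the scatter) leaves 2-fluorophenyl indistinguishable from cyclohexyl, whereas a 3.1-fold higher number from compound 2 to compound 4 (0.49 log units; beyond the scatter) keeps compound 2 modestly apart with the lowest number of the four. No available evidence bears on this result. From the compounds shown here alone, whether bromo, methyl or a nitrile in this place would move the number beyond the scatter remains open.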